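Swapping a piperidine ring for a methoxy-bearing aniline

The source may report more compounds than this note shows. Statements on the series, on what has been measured and on what is new or still open speak of the compounds shown alone.

Measured so far in a functional assay on MDA-MB-231 cells (Homo sapiens) for cytotoxicity, read by MTT assay, with a stated time of 72 h; a lower number here means a stronger inhibitor, a higher number a weaker inhibitor:
- compound 1, `FC(F)(F)c1ccc(CSc2nc(N3CCCCC3)c3ccccc3n2)cc1`: 28400 nM
- compound 2, `FC(F)(F)c1ccc(CSc2nc(Nc3ccccc3)c3ccccc3n2)cc1`: 18400 nM

Compound 1 has the highest of the two numbers in this assay, and its nearest neighbour is compound 2, with the step of a 1.5-fold lower number from compound 1 to compound 2 (0.19 log units; within the scatter). The two compounds therefore cannot be ranked against each other.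

Compound 3, `COc1ccccc1Nc1nc(SCc2ccc(C(F)(F)F)cc2)nc2ccccc12`, has not yet been measured. It differs from compound 1 by (2-methoxyphenyl)amino in place of piperidin-1-yl on an aromatic carbon. The change thus keeps the shared core and the trifluoromethyl-bearing side chain of compound 1 and replaces the piperidin-1-yl group with an aromatic amine that carries a methoxy group.

Among the compounds with values here, the only step that bears on this is the one from compound 1 to compound 2, where the plain anilino group took the place of piperidin-1-yl and the number moved by a 1.5-fold lower number from compound 1 to compound 2 (0.19 log units; within the scatter). Compound 3 carries the same kind of replacement, with one methoxy group added, so a step of similar size is expected, a 1.8-fold lower number from compound 1 to compound 3 (0.25 log units; within the scatter), and no change beyond the scatter is anticipated. For compound 3 the expected value in this assay is 16000 nM, within a range from 5000 nM to 45000 nM.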

Compound 3, half-maximal inhibitory concentration: > 50000 nM
Compound 3 was reported as a limit; the forecaster's own chance of this, stated with the estimate: 10%; at least 3.1-fold (0.49 log units) between middle value and limit.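

In this assay, compound 3 is reported only as a limit of the assay, not as a number: the limit of > 50000 nM in this assay, at which 1 of the 3 values shown sits. Placing methoxy in place of hydrogen on the anilino ring gives an at least 2.7-fold higher number from compound 2 to compound 3 (0.43 log units; beyond the scatter), so this one small addition shifts the result towards a weaker inhibitor by more than the scatter, which the earlier swap of piperidin-1-yl for plain anilino did not do. The full replacement of piperidin-1-yl by (2-methoxyphenyl)amino gives an at least 1.7-fold higher number from compound 1 to compound 3 (0.24 log units; that floor lies within the scatter), and this floor alone does not separate the two compounds, so the cost of the methoxy group shows clearly only against the plain anilino group.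

The compounds shown leave open how large the true rise is, since only a floor can be read, and whether it belongs to methoxy in particular. A methyl group or a chlorine atom in the same place on the anilino ring, or a methoxy group elsewhere on that ring, would be needed to tell those cases apart.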